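Ester chain extension on a nucleoside scaffold

The source may report more compounds than this note shows. Statements on the series, on what has been measured and on what is new or still open speak of the compounds shown alone.

Compound 2 `CC(=O)OC[C@H]1O[C@@H](n2cnc3c(N)ncnc32)[C@@H](O)[C@@H]1O` stands at the lower end of the two numbers obtained so far: in a physicochemical assay for lipophilicity, using the shake flask method, in phosphate buffer, with a stated time of 1 h (on this read-out lower numbers stand for lower lipophilicity and higher numbers for higher lipophilicity), compound 2 gives 0.12, while compound 1 `CC(C)(C)C(=O)OC[C@H]1O[C@@H](n2cnc3c(N)ncnc32)[C@@H](O)[C@@H]1O` gives 1.63. For the measured compounds named here, the one measured step, a number 1.51 log units lower from compound 1 to compound 2 (beyond the scatter), shows that trimming the acyl group from tert-butyl to methyl on the carbonyl carbon lowers the read-out by a large amount. Compound 3 `CCCC(=O)OC[C@H]1O[C@@H](n2cnc3c(N)ncnc32)[C@@H](O)[C@@H]1O` moves the other way: ethyl in place of hydrogen on a saturated chain carbon bound to a carbonyl carbon The acyl group grows from acetyl to propylcarbonyl, a change in the same direction as the step from compound 2 back toward compound 1, though of a smaller extent. On this basis a rise beyond the scatter is expected, estimated as a number 1.00 log units higher from compound 2 to compound 3 (beyond the scatter). For compound 3 in this assay the expected value is 1.12, with a likely range from 0.7 to 1.5.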

Compound 3, partition coefficient: 0.9
The estimate for compound 3 lay 0.22 log units above the measured number, and the stated range covers the measured number.
By their numbers in this assay, from the lowest: compound 2; then compound 3; then compound 1.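

In this assay, the step of a number 0.78 log units higher from compound 2 to compound 3 (beyond the scatter) shows that ethyl in place of hydrogen on a saturated chain carbon bound to a carbonyl carbon is enough by itself to move the read-out, without the tert-butyl group of compound 1. The step of a number 0.73 log units lower from compound 1 to compound 3 (beyond the scatter) shows that propyl and tert-butyl on a carbonyl carbon are also told apart by this read-out, and both steps are modest, with compound 3 lying between the other two compounds. No measurement given here bears on why these groups differ as they do. The compounds shown leave open whether a longer chain, such as pentyl, would raise the read-out further. They also leave open how an amine or a carboxylic acid at the end of the chain would read.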